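A few compounds are considered here, and "the series" means these few. Any claim that something is new, unique, unknown or untested is made for them only; others in the source may bear on it.

Measured so far in a functional assay on U-251 cells (Homo sapiens) for inhibition, read by sulforhodamine B assay, with a stated time of 72 h; a higher number here means that more compound is needed for the effect, a lower number that less compound is needed:
Compound 1 `O=C(/C=C/c1ccc([N+](=O)[O-])o1)c1ccc(Br)cc1`: 21400 nM
Compound 2 `O=C(/C=C/c1ccc([N+](=O)[O-])o1)c1ccc(I)cc1`: 12500 nM

For the measured compounds named here, only one step has been measured: a 1.7-fold lower number from compound 1 to compound 2 (0.23 log units; within the scatter). The two numbers therefore stand level, and compound 2 has no measured neighbour that differs from it beyond the scatter.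

Compound 3 `CSc1ccc(C(=O)/C=C/c2ccc([N+](=O)[O-])o2)cc1` keeps the shared core and changes one group, with methylsulfanyl in place of iodo on an aromatic carbon. This is the same place where bromo and iodo were exchanged, and that exchange gave no step beyond the scatter. Methylsulfanyl is not a halogen, however, so this single step is only a loose guide, and the range must stay wide. No clear move in either direction is expected, and the estimated step is a 1.1-fold higher number from compound 2 to compound 3 (0.05 log units; within the scatter). In this assay the estimate for compound 3 is 14000 nM, expected to fall between 6000 nM and 32000 nM.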

Compound 3, half-maximal effective concentration: 14200 nM
Compound 3: the middle estimate sits 1.0-fold (0.01 log units) below what was measured, and the stated range covers the measured number.
By their numbers in this assay, from the lowest: compounds 2, 3 and 1 (each within the scatter of the next).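

Until now, only two halogens had been compared at this place, on an aromatic carbon para to a large group. Compound 3 extends the comparison to a group that is not a halogen: in this assay, methylsulfanyl brings one more heavy atom than iodo and one hydrogen-bond acceptor, yet both a 1.1-fold higher number from compound 2 to compound 3 (0.06 log units; within the scatter) and a 1.5-fold lower number from compound 1 to compound 3 (0.18 log units; within the scatter) leave the compounds level. No supporting measurement is available to explain this result.

All three groups shown give numbers within the scatter of one another, so it remains open whether any group at this place can separate itself from them, such as an amine, a carboxylic acid or a longer chain. From the compounds shown here alone, the role of the nitro group also stays open, since it is the same in all three compounds.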